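The compounds below may be only part of what the source reports. "The series", "measured", "known", "first", "only" and "open" are said of these compounds alone.

Values in a functional assay with Oryctolagus cuniculus as the target; on this read-out lower numbers stand for stronger inhibition and higher numbers for weaker inhibition:
- Compound 1 `COc1ccc(-c2nc(N=C(N)N)sc2-c2ccc(OC)cc2)cc1`: 31000 nM
- Compound 2 `C/N=C(/NC)Nc1nc(-c2ccc(OC)cc2)c(-c2ccc(OC)cc2)s1`: 970 nM
- Compound 3 `COc1ccc(-c2nc(/N=C(\N)n3ccnc3)sc2-c2ccc(OC)cc2)cc1`: > 100 nM, which is a limit and not a number
- Compound 4 `COc1ccc(-c2nc(CNC(=O)N3CCOCC3)sc2-c2ccc(OC)cc2)cc1`: not yet measured

Compound 3 is known only through (the limit of > 100 nM in this assay, at which 1 of the 3 values shown sits), so its place in the series cannot be fixed.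

The next change, (a group of 10 heavy atoms (6 carbon, 2 nitrogen, 2 oxygen; one six-membered non-aromatic ring with 2 hetero atoms) in place of a group of 8 heavy atoms (4 carbon, 4 nitrogen; one five-membered aromatic ring with 2 hetero atoms), on an aromatic carbon), brings in the (((morpholin-4-yl)carbonyl)amino)methyl group on the aromatic carbon next to the ring nitrogen and next to the ring sulfur. The group that leaves carries no common name.

Going by the values given here, only one measured step at this place has a readable size: a 32-fold lower number from compound 1 to compound 2 (1.50 log units; beyond the scatter). That step is large, so changes here can move the number in this assay well beyond the scatter. The remaining measured steps are a step that the limit leaves unreadable from compound 1 to compound 3 and a step that the limit leaves unreadable from compound 2 to compound 3, and neither gives a size. Among the compounds with values here, no measured compound carries the entering group, so the direction is only a tentative expectation, towards a higher number and weaker inhibition.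

The estimate is placed within the span from compound 2 at 970 nM to compound 1 at 31000 nM, with a wide range. The expected change is a step that the limit leaves unreadable from compound 3 to compound 4. For compound 4 the estimated value is 5000 nM, with an expected range from 500 nM to 40000 nM.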

Compound 4, half-maximal inhibitory concentration: 660 nM
Estimate against measurement, compound 4: 7.6-fold (0.88 log units) above; the measured number falls inside the stated range.
By their numbers in this assay, from the lowest: compounds 4 and 2 (each within the scatter of the next); then compound 1.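

In this assay, the (((morpholin-4-yl)carbonyl)amino)methyl group shows that this position on the aromatic carbon next to the ring nitrogen and next to the ring sulfur accepts a neutral group with a six-membered non-aromatic ring and still matches compound 2, with a 1.5-fold lower number from compound 2 to compound 4 (0.17 log units; within the scatter). Going by these compounds alone, the group in compound 1 now stands apart from two different replacements, since a 47-fold lower number from compound 1 to compound 4 (1.67 log units; beyond the scatter) is a second large step at this place, alongside the one already seen for compound 2; so a large change here does not depend on one particular entering group. The steps that involve compound 3 cannot be read, as compound 3 carries a limit and not a number: the limit of > 100 nM in this assay, at which 1 of the 4 values shown sits.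

The compounds shown leave open which part of the entering group counts: a piperidin-1-yl in place of the morpholin-4-yl, a dimethylamino group in place of the ring, or a plain aminomethyl group without the carbonyl would each separate these parts. They also leave open whether a longer chain between the ring and the urea nitrogen would keep the number in this range.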